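Compound 3 to compound 4: furan-2-yl to 4-hydroxyphenyl

This account rests on a few compounds, and the source may have more. Where it says the series, first, only, none or still open, it means among the compounds named here.

Values in an ADME assay on J774.1 cells (Mus musculus) for cytotoxicity, read by resazurin assay, with a stated time of 48 h; on this read-out lower numbers stand for stronger inhibition and higher numbers for weaker inhibition:
- compound 1 `CCCCn1cc(C(=O)NCc2ccc([N+](=O)[O-])cc2)c(=O)c2cc(F)c(N3CCC(C(N)=O)CC3)cc21`: > 100000 nM, a limit of the assay
- compound 2 `CCCCn1cc(C(=O)NCc2ccc(OC)cc2)c(=O)c2cc(F)c(N3CCC(C(N)=O)CC3)cc21`: 40800 nM
- compound 3 `CCCCn1cc(C(=O)NCc2ccco2)c(=O)c2cc(F)c(N3CCC(C(N)=O)CC3)cc21`: 41400 nM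

Compound 3, at 41400 nM, lies within the scatter of compound 2, and both have numbers, unlike compound 1. Compound 4 `CCCCn1cc(C(=O)NCc2ccc(O)cc2)c(=O)c2cc(F)c(N3CCC(C(N)=O)CC3)cc21` is the next case: 4-hydroxyphenyl in place of furan-2-yl on a saturated chain carbon bound to an amide-type nitrogen, with 4-hydroxyphenyl in place of furan-2-yl on a saturated chain carbon bound to an amide-type nitrogen.

The closest evidence is the exchange of 4-methoxyphenyl for furan-2-yl, which gave a 1.0-fold higher number from compound 2 to compound 3 (0.01 log units; within the scatter). The two steps away from the 4-nitrophenyl compound are larger, an at least 2.4-fold lower number from compound 1 to compound 2 (0.38 log units; beyond the scatter) and an at least 2.4-fold lower number from compound 1 to compound 3 (0.38 log units; beyond the scatter), but they start from a limit. Within the data shown here, no measured compound carries the 4-hydroxyphenyl group itself. With compound 2 as the nearest neighbour, no step beyond the scatter is expected, and the expected step is a 1.1-fold higher number from compound 3 to compound 4 (0.04 log units; within the scatter). The estimate for compound 4 is 45000 nM, with an expected range of 22000 nM to 95000 nM.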

Compound 4, half-maximal inhibitory concentration: 41600 nM
Compound 4: middle estimate off by 1.1-fold (0.03 log units), on the high side, within the range that was stated.
By their numbers in this assay, from the lowest: compounds 2, 3 and 4 (each within the scatter of the next). At a limit, above all of these: compound 1.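

In this assay, the saturated chain carbon bound to the amide-type nitrogen now carries a hydrogen-bond donor without leaving the scatter: 4-hydroxyphenyl in place of furan-2-yl gives a 1.0-fold higher number from compound 3 to compound 4 (0.00 log units; within the scatter), and hydrogen in place of methyl on the oxygen gives a 1.0-fold higher number from compound 2 to compound 4 (0.01 log units; within the scatter). Compound 2, compound 3 and compound 4 therefore stand level, with a five-membered or six-membered aromatic ring and with or without the donor, and only the 4-nitrophenyl compound stands apart. The step of hydroxy in place of nitro, an at least 2.4-fold lower number from compound 1 to compound 4 (0.38 log units; beyond the scatter), starts from the value of compound 1, which is a limit: the limit of > 100000 nM in this assay, at which 1 of the 4 values shown sits.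

On these data alone, the true size of the gap to compound 1 stays open. So does whether a 4-aminophenyl or 4-carboxyphenyl group at this place would stay on the same level.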